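Series notes: benzyloxy variation on the oxime ether scaffold

The source may hold more compounds than are shown below. What is called first, only, known or untested is meant among the compounds shown, and "the series" means these compounds.

Of the compounds shown here, three of the shared core have numbers so far. In a functional assay on SMMC-7721 cells (Homo sapiens) for inhibition, read by MTT assay, with a stated time of 72 h, tested at 1 uM (a lower number here means a weaker effect, a higher number a stronger effect of the compound at the concentration tested), compound 1 `Clc1ccc2c(O/N=C(/C=C/c3ccc(OCc4ccccc4Cl)cc3)\C=C\c3ccccn3)ncnc2c1` gives 18.1%, the lowest of the three. Compound 2 `Fc1ccccc1COc1ccccc1/C=C/C(/C=C/c1ccccn1)=N/Oc1ncnc2cc(Cl)ccc12` gives 94.2% in this assay, and compound 3 `Cc1cccc2ncnc(O/N=C(\C=C\c3ccccn3)/C=C/c3ccccc3OCc3ccc(Cl)cc3Cl)c12` gives 90.8%; both stand well beyond the scatter above compound 1, compound 3 being the nearer of the two and compound 2 the further. Going by the values given here, neither pair differs from compound 1 in a single place, so no single step within the measured set can be isolated.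

Compound 4 `Cc1cccc(COc2ccc(/C=C/C(/C=C/c3ccccn3)=N/Oc3ncnc4cc(Cl)ccc34)cc2)c1` is the next case, not yet measured. It differs from compound 1 in one place: 3-methylphenyl in place of 2-chlorophenyl on a saturated chain carbon bound to an oxygen on an aromatic ring. Among the compounds with values here, with no step of this kind measured, the direction is uncertain; a rise in this assay beyond the scatter is considered possible but not assured, so the expected step from compound 1 is a number 16.9 percentage points higher from compound 1 to compound 4 (beyond the scatter). For compound 4 the estimate in this assay is 35%, with a range from 10% to 75%.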

Compound 4, a percentage reported as inhibition, at one concentration (the size of the read-out at that concentration, not a potency): 78.6%
Compound 4: the middle estimate sits 43.6 percentage points below what was measured; measured number outside the range, above it.
By their numbers in this assay, from the lowest: compound 1; then compound 4; then compounds 3 and 2 (each within the scatter of the next).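

In this assay, going by these compounds alone, 3-methylphenyl in place of 2-chlorophenyl on a saturated chain carbon bound to an oxygen on an aromatic ring gives a number 60.5 percentage points higher from compound 1 to compound 4 (beyond the scatter) and provides the first single-place comparison. The low value of compound 1 is therefore not set by the shared core alone, since this one group change is enough to shift the read-out strongly at the concentration tested. The two groups match in heavy-atom count and in hydrogen-bond donors and acceptors, and no data on the cause of the step are at hand.

The change alters both the substituent and its ring position, so 3-chlorophenyl and 2-methylphenyl would be needed to separate the two. As far as these compounds go, how an unsubstituted phenyl or a 3-aminophenyl group would read at this place also remains open.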